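The source may report more compounds than this note shows. Statements on the series, on what has been measured and on what is new or still open speak of the compounds shown alone.

Compound 1 `Cc1c(OCCCCOc2ccc(C(=O)O)cc2Cl)ccc(C(=O)CC2CCCC2)c1O` gives 82.2% in an assay on HEK293 cells for positive allosteric modulation of metabotropic glutamate receptor 2 (Rattus norvegicus), read by thallium flux, with a stated time of 2.5 min; on this read-out lower numbers stand for smaller maximal responses and higher numbers for larger maximal responses.
Compound 2 `Cc1c(OCCCCOc2ccc(C(=O)O)cc2)ccc(C(=O)CC(C)C)c1O` gives 88% in this assay.
Compound 3 `Cc1c(OCCCCOc2ccc(F)c(C(=O)O)c2)ccc(C(=O)CC2CCCC2)c1O` gives 81% in this assay.

Compound 3 holds the lowest of the three numbers, yet its gaps to compound 1 and to compound 2 both lie within the scatter, so the three compounds cannot be told apart on this read-out. The step to compound 4 `Cc1c(OCCCCOc2ccc(C(=O)O)cc2)ccc(C(=O)CC2CCCC2)c1O` is 4-carboxyphenyl in place of 3-carboxy-4-fluorophenyl on an oxygen on a saturated carbon. Among the compounds with values here, the only measured step that touches the leaving group is a number 1.2 percentage points lower from compound 1 to compound 3 (within the scatter), which exchanged a differently substituted carboxyphenyl for the same 3-carboxy-4-fluorophenyl without moving the number beyond the scatter. Compound 2 already carries the entering 4-carboxyphenyl, though with a different ketone side chain, and its value sits within the scatter of that of compound 3. Nothing in these data therefore points to a step beyond the scatter in this assay. The expected step is a number 4 percentage points higher from compound 3 to compound 4 (within the scatter). Compound 4 is estimated at 85%, with a range from 75% to 95%.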

Compound 4, largest response reached (reported as percent of maximum), in percent of the reference or control that the assay uses: 82.6%
The estimate for compound 4 lay 2.4 percentage points above the measured number, within the range that was stated.
By their numbers in this assay, from the lowest: compounds 3, 1, 4 and 2 (each within the scatter of the next).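

In this assay, the position on an oxygen on a saturated carbon tolerates more than one arrangement of the carboxyphenyl group: 4-carboxyphenyl in place of 3-carboxy-4-fluorophenyl gives a number 1.6 percentage points higher from compound 3 to compound 4 (within the scatter) and the same group is read with no clear change. Hydrogen in place of chloro on an aromatic carbon gives a number 0.4 percentage points higher from compound 1 to compound 4 (within the scatter) and cyclopentyl in place of isopropyl on a saturated chain carbon bound to a carbonyl carbon gives a number 5.4 percentage points lower from compound 2 to compound 4 (within the scatter) and so neither the chloro nor the choice of these two ketone side groups separates the compounds on largest response. No measurement shown here offers an explanation for these readings.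

From the compounds shown here alone, the effect of a primary amide in place of the carboxylic acid, or of a phenyl in place of the cyclopentyl, stays open. Going by these compounds, this read-out gives only the largest response, so how much of each compound is needed to reach it also stays open.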